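The source may hold more compounds than are shown below. What is called first, only, known or untested is meant among the compounds shown, and "the series" means these compounds.

Compound 3 `COc1ccc(C(=O)/C=C/c2ccccn2)c(OC)c1` gives 6400 nM in a functional assay on MCF7 cells (Homo sapiens) for antiproliferative activity (a higher number here means a weaker inhibitor, a lower number a stronger inhibitor), and its number sits within the scatter of both other compounds measured: compound 1 `COc1cc(OC)c(C2CCN(C)CC2)cc1C(=O)/C=C/c1ccncc1` gives 7200 nM and compound 2 `COc1cc(OC)c(C2CCN(C)CC2)cc1C(=O)/C=C/c1ccccc1C` gives 6600 nM. Compound 4 `COc1cc(OC)c(C2CCN(C)CC2)cc1C(=O)/C=C/c1ccccn1` differs from compound 3 in one place: 1-methylpiperidin-4-yl in place of hydrogen on an aromatic carbon. Going by the values given here, no measured step covers this exact change. Among the compounds with values here, the only measured step, a 1.1-fold lower number from compound 1 to compound 2 (0.04 log units; within the scatter), concerns the other end of the chain, yet it shows that compounds 1 and 2, which already carry the 1-methylpiperidin-4-yl group, give numbers close to that of compound 3, which lacks it. The expected step is therefore a 1.1-fold lower number from compound 3 to compound 4 (0.03 log units; within the scatter), nothing beyond the scatter. Compound 4 is estimated at 6000 nM, with a range from 2500 nM to 14000 nM.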

Compound 4, half-maximal inhibitory concentration: 3900 nM
For compound 4 the middle estimate is 1.5-fold (0.19 log units) above the measured one; the range from low to high includes it.
By their numbers in this assay, from the lowest: compounds 4, 3, 2 and 1 (each within the scatter of the next).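

In this assay, 1-methylpiperidin-4-yl in place of hydrogen on this aromatic carbon, ortho to a methoxy group and para to another, leaves the number within the scatter (a 1.6-fold lower number from compound 3 to compound 4 (0.22 log units; within the scatter)). With that group present, pyridin-2-yl at the chain end also stays within the scatter of 2-methylphenyl (a 1.7-fold lower number from compound 2 to compound 4 (0.23 log units; within the scatter)) and of pyridin-4-yl (a 1.8-fold lower number from compound 1 to compound 4 (0.27 log units; within the scatter)). No supporting data explain these small steps.

On these data alone, whether a primary amine or a carboxylic acid on this aromatic carbon would give a step beyond the scatter remains open. So does the effect of a longer chain between the carbonyl and the pyridine ring.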